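This account rests on a few compounds, and the source may have more. Where it says the series, first, only, none or still open, it means among the compounds named here.

Compound 1 `Cc1cc(-c2nc3cc(F)ccc3o2)ccc1NC(=O)CCl` belongs to a small set of anilides built on a shared core, tested in a functional assay on C6 cells (Rattus norvegicus) for cytotoxicity, read by MTT assay, with a stated time of 24 h; a higher number here means a weaker inhibitor, a lower number a stronger inhibitor. In this assay compound 1 gives only > 100000 nM, which is a limit of the assay rather than a measured number. Two relatives give numbers. Compound 3 `O=C(CCl)Nc1ccc(-c2nc3cc(F)ccc3o2)cc1` differs from compound 1 in carrying hydrogen in place of methyl on an aromatic carbon. In this assay compound 3 gives 2990 nM. Compound 2 `Cc1ccc2oc(-c3ccc(NC(=O)CN4CCN(CCCN(C)C)CC4)cc3)nc2c1`, built on the same core but with a different amide side chain, gives 1810 nM. Among the compounds with values here, the one step measured from compound 1 is an at least 33-fold lower number from compound 1 to compound 3 (1.52 log units; beyond the scatter), and it rests on (the limit of > 100000 nM in this assay, at which 1 of the 3 values shown sits), so its true size is not known.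

The next compound, compound 4 `Cc1cc(-c2nc3ccccc3o2)ccc1NC(=O)CCl`, differs from compound 1 only by hydrogen in place of fluoro on an aromatic carbon. No measured step touches this position, so nothing shown speaks for or against a change in this assay. The methyl that compound 3 lacks is still present in compound 4, and compound 1 sits at the limit, so compound 4 is expected to stay near that limit, with an at least 1.2-fold lower number from compound 1 to compound 4 (0.09 log units; that floor lies within the scatter). The estimate for compound 4 is 80000 nM, within a range from 15000 nM to 300000 nM.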

Compound 4, half-maximal inhibitory concentration: 27200 nM
Compound 4: middle estimate off by 2.9-fold (0.47 log units), on the high side; the range from low to high includes it.
By their numbers in this assay, from the lowest: compounds 2 and 3 (each within the scatter of the next); then compound 4. At a limit, above all of these: compound 1.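

In this assay, within the data shown here, putting hydrogen in place of fluoro on this aromatic carbon gives an at least 3.6-fold lower number from compound 1 to compound 4 (0.56 log units; beyond the scatter), so this position, which no earlier step touched, does affect the read-out even with the methyl still in place. Together with the step of an at least 33-fold lower number from compound 1 to compound 3 (1.52 log units; beyond the scatter), this means that each of the two single changes measured from compound 1, losing the fluoro or losing the methyl, moves the number down, though neither size can be fixed and the two cannot be ranked. Compound 1 stands at a limit, so the new step is only a floor and its true size remains unknown: the limit of > 100000 nM in this assay, at which 1 of the 4 values shown sits.

The compounds shown do not say whether losing the fluoro would matter in the same way on a core without the methyl, since the only partner for such a comparison would be a compound carrying neither group. They also leave open what other groups on this aromatic carbon would do, such as chloro, methoxy or an amine, and so whether the change seen here is specific to fluoro or would appear with other replacements too.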